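The source may report more compounds than this note shows. Statements on the series, on what has been measured and on what is new or still open speak of the compounds shown alone.

In an ADME assay on K562 cells (Homo sapiens) for antiproliferative activity (a higher number here means a weaker inhibitor, a lower number a stronger inhibitor), compound 1 (`COc1ccc2nccc(CC[C@H]3CC[C@H](NCc4ccc(Cl)c(Cl)c4)CC3)c2c1`) gives "not determined" (no result reported) and so offers no number for comparison. Compound 2 (`COc1ccc2nccc(CC[C@H]3OC[C@H](NCc4ccc(Cl)c(Cl)c4)CO3)c2c1`) gives 20000 nM as its result, and compound 3 (`COc1ccc2nccc(CC[C@H]3CC[C@H](NCc4ccc5c(c4)OCCO5)CC3)c2c1`) gives 4200 nM as its result. Compound 2 therefore holds the higher of the two numbers available, and its gap to compound 3 lies beyond the scatter. These two compounds differ in more than one place, so their values cannot be tied to any single structural change.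

Compound 4 (`COc1ccc2nccc(CC[C@H]3OC[C@H](NCc4cc5c(cn4)OCCC5)CO3)c2c1`) keeps the rest of compound 2 and changes one group: a group of 10 heavy atoms (8 carbon, 1 nitrogen, 1 oxygen; one six-membered non-aromatic ring with 1 hetero atom, one six-membered aromatic ring with 1 hetero atom) in place of a group of 8 heavy atoms (6 carbon, 2 chlorine; one six-membered aromatic ring of carbon only), on a saturated chain carbon bound to an amine nitrogen. Among the measured compounds shown here, no measured pair isolates this replacement, so the expectation rests on little. The closest anchor is compound 2 at 20000 nM and nothing measured points to a large move. The expected 1.5-fold higher number from compound 2 to compound 4 (0.18 log units; within the scatter) is small and upward, within the scatter. Compound 4 is expected near 30000 nM with 10000 nM to 90000 nM as the estimated range.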

Compound 4, half-maximal inhibitory concentration: 32000 nM
The estimate for compound 4 lay 1.1-fold (0.03 log units) below the measured number, within the range that was stated.
By their numbers in this assay, from the lowest: compound 3; then compounds 2 and 4 (each within the scatter of the next).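

In this assay, replacing 3,4-dichlorophenyl on a saturated chain carbon bound to an amine nitrogen with the group of 10 heavy atoms gives a 1.6-fold higher number from compound 2 to compound 4 (0.20 log units; within the scatter). Among the compounds shown here, this is the first step available at this position, and it shows that the read-out stays within the scatter even though the incoming group has a non-aromatic ring, a hetero atom in its aromatic ring and 2 hydrogen-bond acceptors where the departing group has 0. No supporting data on this pair offer an explanation for the result.

The compounds shown leave open whether a different group at this position, such as an unsubstituted phenyl or a carboxylic acid, would move the number beyond the scatter. They also leave open whether this same replacement would give a similar step on the core of compound 3.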